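Naphthyl triazolothiadiazine series: para-substituent swap, estimate for compound 4

The compounds below may be only part of what the source reports. "The series", "measured", "known", "first", "only" and "open" are said of these compounds alone.

Measured compounds, with their numbers in a functional assay on MCF7 cells (Homo sapiens) for inhibition, read by sulforhodamine B assay, with a stated time of 72 h; a higher number here means a weaker inhibitor, a lower number a stronger inhibitor:
- compound 1 `COc1ccc2cc(C(C)c3nnc4n3N=C(c3ccc(OC(F)(F)F)cc3)CS4)ccc2c1`: 8800 nM
- compound 2 `COc1ccc2cc(C(C)c3nnc4n3N=C(c3ccc(F)cc3)CS4)ccc2c1`: 15800 nM
- compound 3 `COc1ccc(C2=Nn3c(nnc3C(C)c3ccc4cc(OC)ccc4c3)SC2)cc1`: 6600 nM

Compound 3 has the lowest of the three numbers in this assay. Against compound 1 the gap is a 1.3-fold lower number from compound 1 to compound 3 (0.12 log units; within the scatter), so the two stand together. Against compound 2 the gap is a 2.4-fold lower number from compound 2 to compound 3 (0.38 log units; beyond the scatter), a modest step beyond the scatter.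

Compound 4 `COc1ccc2cc(C(C)c3nnc4n3N=C(c3ccc(Cl)cc3)CS4)ccc2c1` is not yet measured. It differs from compound 3 by chloro in place of methoxy on an aromatic carbon. The step that bears on it most directly is the reverse of the methoxy-for-fluoro change, a 2.4-fold lower number from compound 2 to compound 3 (0.38 log units; beyond the scatter), which moved the number down by a modest amount. The other change on the same ring, a 1.3-fold lower number from compound 1 to compound 3 (0.12 log units; within the scatter), stayed within the scatter. A halogen in place of methoxy is therefore expected to push the number in this assay up again, by roughly the size seen between compound 2 and compound 3, though a result within the scatter cannot be excluded. The expected step is a 1.7-fold higher number from compound 3 to compound 4 (0.22 log units; within the scatter). Compound 4 is estimated at 11000 nM, in the range 5500 nM to 22000 nM.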

Compound 4, half-maximal inhibitory concentration: 10100 nM
Estimate against measurement, compound 4: 1.1-fold (0.04 log units) above, within the range that was stated.
By their numbers in this assay, from the lowest: compounds 3, 1, 4 and 2 (each within the scatter of the next, the first and the last beyond it).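

In this assay, chloro on this aromatic carbon, para to a large group, cannot be told apart from any of the three other groups: methoxy (a 1.5-fold higher number from compound 3 to compound 4 (0.18 log units; within the scatter)), fluoro (a 1.6-fold lower number from compound 2 to compound 4 (0.19 log units; within the scatter)) and trifluoromethoxy (a 1.1-fold higher number from compound 1 to compound 4 (0.06 log units; within the scatter)) all lie within the scatter of it. Compound 4 therefore fills the gap between the only pair of these compounds separated beyond the scatter (a 2.4-fold lower number from compound 2 to compound 3 (0.38 log units; beyond the scatter)), and the fluoro-to-methoxy swap remains the one change here that exceeds it. Nothing measured here speaks to a cause for these differences.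

On these data alone, whether an amine, a carboxylic acid or a longer chain at this position would move the number clearly outside the span of these four compounds stays open. Also open, as far as these compounds go, is whether the same order of groups would hold with a different group on the other side of the shared core.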